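Swapping Bromine for Methoxy on the Benzylidene Ring

A few compounds are considered here, and "the series" means these few. Any claim that something is new, unique, unknown or untested is made for them only; others in the source may bear on it.

Measured compounds and their values in an ADME assay on NIH3T3 cells (Mus musculus) for cytotoxicity, read by XTT assay, with a stated time of 24 h; a lower number here means a stronger inhibitor, a higher number a weaker inhibitor:
- compound 1, `Cn1nnnc1SCC(=O)N/N=C/c1ccccc1`: 9700000 nM
- compound 2, `Cn1nnnc1SCC(=O)N/N=C/c1ccccc1F`: 2000000 nM
- compound 3, `Cn1nnnc1SCC(=O)N/N=C/c1ccccc1Br`: 20000 nM

Compound 3 gives the lowest number of the three in this assay. Its nearest neighbour is compound 2, reached by a 100-fold lower number from compound 2 to compound 3 (2.00 log units; beyond the scatter), and compound 1 lies furthest away, reached by a 490-fold lower number from compound 1 to compound 3 (2.69 log units; beyond the scatter). Within this small set, every substituent placed on that aromatic carbon has lowered the number, and the bromo has done so far more than the fluoro, as the step of a 4.9-fold lower number from compound 1 to compound 2 (0.69 log units; beyond the scatter) shows.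

Compound 4, `COc1ccccc1/C=N/NC(=O)CSc1nnnn1C`, differs from compound 3 by methoxy in place of bromo on an aromatic carbon. Among the measured compounds shown here, no measured step involves a methoxy, so the bearing steps are only those above: two substituents on this carbon gave two very different outcomes, and the methoxy is a third kind of group. The bromo appears to be doing something the fluoro does not, and removing it is expected to give back part of that gain. Compound 4 is therefore expected to show a higher number than compound 3, with the step of a 25-fold higher number from compound 3 to compound 4 (1.40 log units; beyond the scatter) expected to be large but to stop well short of the level of compound 1. The estimate for compound 4 is 500000 nM, within a range from 50000 nM to 5000000 nM.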

Compound 4, half-maximal inhibitory concentration: 3160000 nM
For compound 4 the middle estimate is 6.3-fold (0.80 log units) below the measured one, and the stated range covers the measured number.
By their numbers in this assay, from the lowest: compound 3; then compounds 2 and 4 (each within the scatter of the next); then compound 1.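

In this assay, replacing the bromo with methoxy on this aromatic carbon removes nearly all of the drop seen with bromo (a 160-fold higher number from compound 3 to compound 4 (2.20 log units; beyond the scatter)), so among the groups shown, the large drop comes only with bromo. The methoxy and fluoro compounds cannot be told apart here (a 1.6-fold higher number from compound 2 to compound 4 (0.20 log units; within the scatter)), so a group with an oxygen and a carbon gives much the same result as a single fluorine. Methoxy still keeps a modest step relative to plain hydrogen (a 3.1-fold lower number from compound 1 to compound 4 (0.49 log units; beyond the scatter)), which means all three groups give lower numbers than hydrogen, but only bromo gives a large step.

From the compounds shown here alone, it remains open whether a chloro or iodo group would behave like the bromo, or whether an amine here would follow the methoxy. No available evidence bears on why the bromo stands apart.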